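The compounds below may be only part of what the source reports. "The series", "measured", "known", "first", "only" and "open" are said of these compounds alone.

Within the data shown here, compound 2 `CCN(CC)C(=O)Cc1c(-c2ccc(OCc3ccc(F)cc3)cc2)nn2c(C)cc(C)nc12` stands lowest of the two numbers so far in an assay on isolated protein (kidney, strain Wistar) for displacement of a labelled ligand from Translocator protein (Rattus norvegicus), read by scintillation counting, with a stated time of 90 min; a lower number here means a stronger inhibitor, a higher number a weaker inhibitor: compound 2 gives 0.77 nM, while compound 1 `CCN(CC)C(=O)Cc1c(-c2ccc(OC(C)C)cc2)nn2c(C)cc(C)nc12`, the only other measured member, gives 2.2 nM. Among the measured compounds shown here, the one step in hand, a 2.9-fold lower number from compound 1 to compound 2 (0.46 log units; beyond the scatter), swaps an isopropyl on the aryl oxygen for a 4-fluorobenzyl. Compound 3 `CCN(CC)C(=O)Cc1c(-c2ccc(OCc3cccc(C(F)(F)F)c3)cc2)nn2c(C)cc(C)nc12` differs from compound 2 by 3-(trifluoromethyl)phenyl in place of 4-fluorophenyl on a saturated chain carbon bound to an oxygen on an aromatic ring. For the measured compounds named here, no measured step changes the substituent on that benzyl ring, so the isopropyl-to-benzyl step gives only indirect guidance: it establishes that a benzyl at this oxygen is tolerated with a modest gain, but says nothing about moving from a fluorine to a trifluoromethyl on that ring. Going by the values given here, with no direct precedent, the working expectation in this assay is no change beyond the scatter. The expected step is therefore a 1.3-fold higher number from compound 2 to compound 3 (0.11 log units; within the scatter). Compound 3 is estimated at 1 nM, with a range from 0.4 nM to 2.5 nM.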

Compound 3, inhibition constant: 0.67 nM
Compound 3: middle estimate off by 1.5-fold (0.17 log units), on the high side; measured number inside the range.
By their numbers in this assay, from the lowest: compounds 3 and 2 (each within the scatter of the next); then compound 1.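

In this assay, the substituent on the benzyl ring now has its first direct comparison: 3-(trifluoromethyl)phenyl in place of 4-fluorophenyl gives a 1.1-fold lower number from compound 2 to compound 3 (0.06 log units; within the scatter) so these two groups cannot be told apart at this position, although 10 heavy atoms enter where 7 leave. Replacing isopropyl with a second substituted benzyl also gives a lower number, a 3.3-fold lower number from compound 1 to compound 3 (0.52 log units; beyond the scatter) so the advantage over isopropyl is not confined to the 4-fluorobenzyl of compound 2. Nothing available accounts for the close match between the two benzyl groups.

Between compound 2 and compound 3, both the substituent and its place on the ring change, so the effect of each remains unresolved. Also open, from the compounds shown here alone, is whether an unsubstituted benzyl, or a benzyl ring carrying a methoxy group or a carboxylic acid, would fall in the same range.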